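Replacing the Ring Nitrogen: Solubility Expectation for Compound 3

A few compounds are considered here, and "the series" means these few. Any claim that something is new, unique, unknown or untested is made for them only; others in the source may bear on it.

Compound 2 `C[C@@H]1CN([C@@H](C)CO)C(=O)c2cccc(NC(=O)Nc3cccc4cnccc34)c2O[C@H]1CN(C)S(=O)(=O)c1ccc2c(c1)OCCO2` gives 60500 nM in a physicochemical assay for solubility, read by HPLC, in phosphate buffer, measured as thermodynamic solubility, with a stated time of 24 h, at pH 7.4 (on this read-out lower numbers stand for lower solubility and higher numbers for higher solubility), the higher of the two measured numbers; compound 1 `C[C@@H]1CN([C@@H](C)CO)C(=O)c2cccc(NC(=O)Nc3cccc4cccnc34)c2O[C@H]1CN(C)S(=O)(=O)c1ccc2c(c1)OCCO2` gives 1800 nM. Going by the values given here, the only measured step, a 34-fold higher number from compound 1 to compound 2 (1.53 log units; beyond the scatter), moved the ring nitrogen but kept it. Compound 3 `C[C@@H]1CN([C@@H](C)CO)C(=O)c2cccc(NC(=O)Nc3cccc4ccccc34)c2O[C@H]1CN(C)S(=O)(=O)c1ccc2c(c1)OCCO2` differs from compound 2 by naphthalen-1-yl in place of isoquinolin-5-yl on an amide-type nitrogen, so that step bears only indirectly on it. Without a closer comparison, the expectation is a moderate step downward, a 6.1-fold lower number from compound 2 to compound 3 (0.78 log units; beyond the scatter). Compound 3 is therefore estimated at 10000 nM, with a likely range from 2000 nM to 40000 nM.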

Compound 3, solubility: 100 nM
Beside the measured number, compound 3's estimate is 100-fold (2.00 log units) above it, and the stated range ends above it.
By their numbers in this assay, from the lowest: compound 3; then compound 1; then compound 2.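

Swapping isoquinolin-5-yl for naphthalen-1-yl, which has carbon only in both rings, gives a 610-fold lower number from compound 2 to compound 3 (2.78 log units; beyond the scatter) in this assay and is the first change here that removes the ring nitrogen rather than moving it. Swapping quinolin-8-yl for the same group gives an 18-fold lower number from compound 1 to compound 3 (1.26 log units; beyond the scatter) as well, so compound 3 lies below both compounds that carry a ring nitrogen, wherever that nitrogen sits. Nothing measured here explains the size of these steps.

Still open, from the compounds shown here alone, is how an amine or a carboxylic acid on the naphthalen-1-yl ring would read in this assay.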